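A few compounds are considered here, and "the series" means these few. Any claim that something is new, unique, unknown or untested is made for them only; others in the source may bear on it.

Compound 1 `O[C@@H]1Cc2ccccc2N[C@H](c2ccccc2Cl)C1` gives > 300000 nM in an ADME assay on THP-1 cells (Homo sapiens) for cytotoxicity, read by MTT assay, with a stated time of 72 h (a higher number here means that more compound is tolerated, a lower number that less compound is tolerated), which is a limit of the assay.
Compound 2 `O[C@@H]1Cc2ccccc2N[C@H](c2ccccc2F)C1` gives > 300000 nM in this assay, also a limit of the assay.

Among the compounds with values here, compound 2 thus stands at the top of what this assay can report, as does the only other measured compound: the limit of > 300000 nM in this assay, at which 2 of the 2 values shown sit. Within the data shown here, the one measured step, a step that the two limits leave unreadable from compound 1 to compound 2, is therefore unreadable in size and direction.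

Compound 3 `O[C@@H]1Cc2cc(Cl)ccc2N[C@H](c2ccccc2F)C1` differs from compound 2 by chloro in place of hydrogen on an aromatic carbon. Among the measured compounds shown here, no measured step touches that position or that kind of change, and the single step that exists carries no readable size. On that basis the step from compound 2 to compound 3 is expected to be a number no higher from compound 2 to compound 3 (the limit leaves the size open), no change beyond the scatter, with the outcome most likely once more a limit. Compound 3 is therefore estimated at 300000 nM, within a range from 80000 nM to 300000 nM.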

Compound 3, half-maximal cytotoxic concentration: 110000 nM
The estimate for compound 3 lay 2.7-fold (0.44 log units) above the measured number, and the stated range covers the measured number.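

Chloro in place of hydrogen on an aromatic carbon of the fused system gives the first step with a readable direction in this assay, with an at least 2.7-fold lower number from compound 2 to compound 3 (0.43 log units; beyond the scatter) as its result. From the compounds shown here alone, the value of compound 2 is a limit of the assay, so this step fixes only a smallest size and the full size stays unknown. Substitution at this place thus brings compound 3 to a number rather than a limit, which neither earlier compound gave: the limit of > 300000 nM in this assay, at which 2 of the 3 values shown sit.

The compounds shown leave open whether this lower number is particular to chloro, since a methoxy, an amine or a carboxylic acid on the same aromatic carbon is not among them. They also leave open whether chloro at this place would lower the number the same way in compound 1, which carries chloro rather than fluoro on its other aromatic ring.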